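This account rests on a few compounds, and the source may have more. Where it says the series, first, only, none or still open, it means among the compounds named here.

Measured in an assay on isolated protein for inhibition of Indoleamine 2,3-dioxygenase 2 (Homo sapiens); on this read-out lower numbers stand for stronger inhibition and higher numbers for weaker inhibition:

compound 1 `CC(C)(O)c1cn(CCNc2nonc2/C(=N/O)Nc2ccc(F)c(Br)c2)nn1` gives 726 nM
compound 2 `CCC(C)(O)c1cn(CCNc2nonc2/C(=N/O)Nc2ccc(F)c(Br)c2)nn1` gives 958 nM
compound 3 `CC(OCCO)c1cn(CCNc2nonc2/C(=N/O)Nc2ccc(F)c(Br)c2)nn1` gives 930 nM

Compound 4 `CC(C)(OCCO)c1cn(CCNc2nonc2/C(=N/O)Nc2ccc(F)c(Br)c2)nn1` has not yet been measured.

The three measured compounds share a common core and differ only in the group carried on one aromatic carbon. Their numbers sit close together: a 1.3-fold higher number from compound 1 to compound 2 (0.12 log units; within the scatter), a 1.3-fold higher number from compound 1 to compound 3 (0.11 log units; within the scatter) and a 1.0-fold lower number from compound 2 to compound 3 (0.01 log units; within the scatter). None of these steps is larger than the scatter of this assay, so the three compounds cannot be told apart on this read-out.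

The change from compound 3 to compound 4 is of the same kind as the change from compound 1 to compound 2. From compound 1 to compound 2 the change is methyl in place of hydrogen on a saturated chain carbon, two bonds along the chain from an aromatic carbon and an oxygen on a saturated carbon and it made the step of a 1.3-fold higher number from compound 1 to compound 2 (0.12 log units; within the scatter). From compound 3 to compound 4 the change is methyl in place of hydrogen on a saturated chain carbon bound to an aromatic carbon, an oxygen on a saturated carbon and a saturated chain carbon. The two places are not the same: in the first pair the methyl enters two bonds along the chain from an aromatic carbon and an oxygen on a saturated carbon, in the second pair it enters on a carbon bound to an aromatic carbon, an oxygen on a saturated carbon and a saturated chain carbon. The two cores also differ: 1-(2-hydroxyethoxy)ethyl in place of 1-hydroxy-1-methylethyl on an aromatic carbon.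

Going by the values given here, for compound 4 the expected step is a 1.2-fold higher number from compound 3 to compound 4 (0.07 log units; within the scatter), because the one measured example of this kind of change gave a 1.3-fold higher number from compound 1 to compound 2 (0.12 log units; within the scatter). Compound 4 is therefore estimated at 1100 nM in this assay, with a likely range from 500 nM to 2500 nM.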

Compound 4, half-maximal inhibitory concentration: 1170 nM
Compound 4: the middle estimate sits 1.1-fold (0.03 log units) below what was measured; the range from low to high includes it.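

The new step is a 1.3-fold higher number from compound 3 to compound 4 (0.10 log units; within the scatter) in this assay, and the other two steps that reach compound 4, a 1.2-fold higher number from compound 2 to compound 4 (0.09 log units; within the scatter) and a 1.6-fold higher number from compound 1 to compound 4 (0.21 log units; within the scatter), also stay inside the usual scatter of the measurement. Set side by side, the methyl change reads the same on both cores: the same change on two cores in this assay, a 1.3-fold higher number (0.12 log units; within the scatter) from compound 1 to compound 2 and a 1.3-fold higher number (0.10 log units; within the scatter) from compound 3 to compound 4, 1.0-fold (0.02 log units) apart, within the scatter of two such steps. Going by these compounds alone, this shows that on these two cores the change gave no step that can be told apart from repeat-to-repeat noise, but it does not show a real methyl effect that carries from one core to another, and two cores make no rule for the whole series.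

The compounds shown vary only the group on one aromatic carbon, and every one of them keeps a hydroxyl group in that group, so it stays open whether an amine or a carboxylic acid in its place, or a chain longer than 2-hydroxyethyl on the oxygen, would move the number beyond the scatter. As far as these compounds go, it also stays open how the same methyl change would read on a core whose number lies far from those seen here.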